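A few compounds are considered here, and "the series" means these few. Any claim that something is new, unique, unknown or untested is made for them only; others in the source may bear on it.

Going by the values given here, compound 1 `C=CCn1c(=O)/c(=C\c2cccc(Br)c2)[nH]c(=O)/c1=C\c1ccccc1OC` is the only member of this small set with a number against its name. In a functional assay on MCF7 cells (Homo sapiens) for cytotoxicity, read by CCK-8 assay, with a stated time of 72 h (on this read-out higher numbers stand for weaker inhibition and lower numbers for stronger inhibition), compound 1 gives 5400 nM, a weak figure on its own. Among the compounds with values here, the one other tested member, compound 2 `C=CCn1c(=O)/c(=C\c2cc(OC)c(OC)c(OC)c2)[nH]c(=O)/c1=C\c1cccc(Br)c1`, carries only the entry "not active" (no number reported) in this assay, with no number behind it, so compound 1 cannot be ranked against it beyond noting that compound 1 at least returned a value where compound 2 did not. Within the data shown here, no step between measured compounds can be read from these two entries.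

Compound 3 `C=CCn1c(=O)/c(=C\c2cc(Br)ccc2F)[nH]c(=O)/c1=C\c1ccccc1OC` is the untested member that follows from compound 1 by a single change, (fluoro in place of hydrogen on an aromatic carbon). Nothing measured here bears on what a fluoro group at that position does, so the expectation rests on the small size of the change and on the weak starting value of compound 1 in this assay. The expected step from compound 1 to compound 3 is a 1.1-fold lower number from compound 1 to compound 3 (0.03 log units; within the scatter), that is, no shift beyond the scatter in either direction. Compound 3 is therefore expected to give about 5000 nM, within a range from 1800 nM to 15000 nM.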

Compound 3, half-maximal inhibitory concentration: 28100 nM
Compound 3: middle estimate off by 5.6-fold (0.75 log units), on the low side; measured number above the stated range.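

In this assay the change from 3-bromophenyl to 5-bromo-2-fluorophenyl gives a 5.2-fold higher number from compound 1 to compound 3 (0.72 log units; beyond the scatter), so this aromatic carbon, ortho to a large group and para to a bromo group, does not tolerate even a single added fluoro atom without a shift in the read-out. Going by these compounds alone, the earlier compounds offered no step at all, and compound 2 has no number from which one could be read; this is therefore the first change in the set whose size can be stated, and it runs toward weaker inhibition, leaving compound 1 the stronger of the pair. Nothing available accounts for the shift.

The compounds shown leave open whether a chloro group, a methyl group, a methoxy group or an amine on the same aromatic carbon would move the number as far as fluoro does, or in the opposite direction. They also leave open whether a fluoro group on another carbon of that ring would give a similar step, and whether the step would carry over to a compound with different groups elsewhere on the shared core.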